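The compounds below may be only part of what the source reports. "The series", "measured", "known", "first", "only" and "open" are said of these compounds alone.

Compound 1 `COc1ccc(CCCCCCCCOc2ccc(C[S+]([O-])c3cccc(C(=O)O)c3)nc2/C=C/C(=O)O)cc1`: 151 nM
Compound 2 `COc1ccc(CCCCCCCCOc2ccc(CSc3cccc(C(=O)O)c3)nc2/C=C/C(=O)O)cc1`: 80 nM

The two measured compounds share one core and differ only in the group on the saturated chain carbon bound to an aromatic carbon. In an assay for binding affinity to leukotriene B4 receptor 1 (Homo sapiens) (a higher number here means a weaker inhibitor, a lower number a stronger inhibitor), the step of a 1.9-fold lower number from compound 1 to compound 2 (0.28 log units; within the scatter) lies within the scatter. Within the data shown here, compound 2 thus shows the lower of the two numbers, but its only neighbour, compound 1, sits within the scatter of it, so the two cannot be ranked against each other.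

Compound 3 `COc1ccc(CCCCCCCCOc2ccc(CSc3cccc(N)c3)nc2/C=C/C(=O)O)cc1` has not yet been measured in this assay. It differs from compound 2 by amino in place of carboxy on an aromatic carbon. Among the measured compounds shown here, no measured step bears on this change: the single step on record alters a different place, and no measured pair differs by carboxy against amino. The expectation therefore rests on the structural change alone and carries a wide range. Compound 3 is expected to give 300 nM in this assay, with a range from 80 nM to 1500 nM. The step from compound 2 to compound 3 is expected to read a 3.8-fold higher number from compound 2 to compound 3 (0.57 log units; beyond the scatter), a move toward a higher number, although a result within the scatter of compound 2 would not be surprising.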

Compound 3, inhibition constant: 34 nM
Compound 3: middle estimate off by 8.8-fold (0.95 log units), on the high side; the whole stated range lies above it.
By their numbers in this assay, from the lowest: compound 3; then compounds 2 and 1 (each within the scatter of the next).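

Among these compounds, the earlier compounds varied only the group on the saturated chain carbon, and this result is the first to show that the carboxy on the aromatic ring can be replaced without loss in this assay: amino in place of carboxy, with two fewer heavy atoms at that place, gives a 2.4-fold lower number from compound 2 to compound 3 (0.37 log units; beyond the scatter). Among the compounds shown here, the carboxy at this place is therefore not needed for a number at this level, at least on the core of compound 2, and the change is the first to move the number beyond the scatter in a single step. For the compounds shown here, the wider step, a 4.4-fold lower number from compound 1 to compound 3 (0.65 log units; beyond the scatter), spans both the change at this place and the one that separates compound 1 from compound 2, so it cannot be assigned to either alone, and nothing on record explains why the amino compound gives the lower number.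

Going by these compounds, whether a hydroxyl, an amide or a plain hydrogen at this place would read closer to the amino or to the carboxy remains open. Also open, on these data alone, is whether amino in place of carboxy would give a similar step on the core of compound 1.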